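Replacing an Ethyl Group with a Methylbenzyl Group on the Core

A few compounds are considered here, and "the series" means these few. Any claim that something is new, unique, unknown or untested is made for them only; others in the source may bear on it.

Of the compounds shown here, three with a shared core have been measured in a functional assay on HeLa cells (Homo sapiens) for cytotoxicity, read by cell counting, with a stated time of 4 days; a higher number here means a weaker inhibitor, a lower number a stronger inhibitor. Compound 1 `CC(C)(C)c1ccc(CN2C(=O)S/C(=C\c3ccc(N)cc3)C2=O)cc1` gives 53000 nM in this assay. Compound 2 `Nc1ccc(/C=C2\SC(=O)N(Cc3ccc(Cl)cc3)C2=O)cc1` gives 77000 nM in this assay, and the step was a 1.5-fold higher number from compound 1 to compound 2 (0.16 log units; within the scatter). Compound 3 `CCN1C(=O)S/C(=C\c2ccc(N)cc2)C1=O` gives 108000 nM in this assay, the highest of the three numbers; its gap to compound 1 lies beyond the scatter, while its gap to compound 2 lies within it, so compound 2 and compound 3 cannot be told apart. The step between them was a 1.4-fold higher number from compound 2 to compound 3 (0.15 log units; within the scatter).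

Compound 4 `Cc1ccc(CN2C(=O)S/C(=C\c3ccc(N)cc3)C2=O)cc1` has not yet been measured. It differs from compound 3 as follows: 4-methylphenyl in place of methyl on a saturated chain carbon bound to an amide-type nitrogen in a ring.

Among the compounds with values here, the one step that bears on this change is the one from compound 2 to compound 3, where the same kind of exchange ran the other way and gave a step within the scatter. Compound 1 and compound 2, which both carry an aromatic ring on that chain carbon, sit at the lower numbers. Compound 4 is therefore expected to give a step of a 1.7-fold lower number from compound 3 to compound 4 (0.22 log units; within the scatter), a modest lowering that may not exceed the scatter. The estimate for compound 4 is 65000 nM, with a range from 30000 nM to 130000 nM.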

Compound 4, half-maximal inhibitory concentration: > 250000 nM
Compound 4: a limit, no number; the forecaster's own chance of this, stated with the estimate: 15%; middle value at least 3.8-fold (0.58 log units) away from the limit.
By their numbers in this assay, from the lowest: compounds 1, 2 and 3 (each within the scatter of the next, the first and the last beyond it). At a limit, above all of these: compound 4.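

Compound 4 gives only a limit of the assay, not a number, in this assay: the limit of > 250000 nM in this assay, at which 1 of the 4 values shown sits. The change to 4-methylphenyl on a saturated chain carbon bound to an amide-type nitrogen in a ring gives an at least 2.3-fold higher number from compound 3 to compound 4 (0.36 log units; beyond the scatter) and so runs against the lower numbers of compound 1 and compound 2, while on an aromatic carbon methyl in place of chloro gives an at least 3.2-fold higher number from compound 2 to compound 4 (0.51 log units; beyond the scatter) and methyl in place of tert-butyl gives an at least 4.7-fold higher number from compound 1 to compound 4 (0.67 log units; beyond the scatter) in the same direction. The earlier step between chloro and tert-butyl lay within the scatter, so only compound 4 shows that an aromatic ring on this chain carbon does not by itself go with a lower number and that the group on that ring can matter.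

The compounds shown leave open whether a fluoro, a methoxy or a carboxylic acid on that aromatic carbon would fall with compound 1 and compound 2 or with compound 4. They also leave open how a longer chain in place of the 4-methylphenyl would compare with compound 3.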